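Dropping One Fluoro from the Most Active Furan Hydrazide

The source may report more compounds than this note shows. Statements on the series, on what has been measured and on what is new or still open speak of the compounds shown alone.

Measured so far in a functional assay on Bel-7402 cells (Homo sapiens) for inhibition, read by sulforhodamine B assay, with a stated time of 48 h, tested at 10 uM; a lower number here means less inhibition of growth, a higher number more inhibition of growth at the concentration tested:
compound 1 `O=C(N/N=C/c1ccc(-c2ccc(Cl)cc2)o1)c1ccccc1` gives -7.17%
compound 2 `O=C(N/N=C/c1ccccc1)c1ccc(-c2ccc(Cl)cc2)o1` gives 2.28%
compound 3 `O=C(N/N=C/c1ccc(-c2ccc(F)cc2F)o1)c1ccccc1O` gives 63.4%

Compound 3 stands highest of the three numbers in this assay . Its nearest neighbour is compound 2, whose value lies beyond the scatter below it, and compound 1 lies further below still, also beyond the scatter. Compound 3 is thus the only one of the three that shows clear growth inhibition at the concentration tested.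

Compound 4 `O=C(N/N=C/c1ccc(-c2ccc(F)cc2)o1)c1ccccc1O` has not yet been measured. It differs from compound 3 in one place: hydrogen in place of fluoro on an aromatic carbon. Among the measured compounds shown here, no step between two measured compounds matches this change, so its size is not known from the numbers at hand. Because compound 3 gives 63.4% and the change removes only one fluoro, the step in this assay from compound 3 to compound 4 is expected to be small, likely within the scatter or a modest loss: a number 11.4 percentage points lower from compound 3 to compound 4 (beyond the scatter). Compound 4 is estimated to give 52%, with a range from 25% to 75%.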

Compound 4, percent growth inhibition at one concentration: 81.6%
Compound 4: the middle estimate sits 29.6 percentage points below what was measured; measured number outside the range, above it.
By their numbers in this assay, from the lowest: compounds 1 and 2 (each within the scatter of the next); then compound 3; then compound 4.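

In this assay, the change from 2,4-difluorophenyl to 4-fluorophenyl gives a number 18.2 percentage points higher from compound 3 to compound 4 (beyond the scatter), so the fluoro ortho to a large group is not needed for growth inhibition at the concentration tested, and hydrogen in its place does better. Among the compounds shown here, this is the first pair of measured compounds that differ in one place, so the effect of a single change can now be read directly from two numbers. Nothing at hand explains why hydrogen at this place gives the higher number.

The compounds shown leave open how a methyl group, a methoxy group or an amine at this same place would compare with hydrogen and fluoro. They also leave open whether compound 4 would keep its growth inhibition if an amine replaced its remaining fluoro.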